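The source may report more compounds than this note shows. Statements on the series, on what has been measured and on what is new or still open speak of the compounds shown alone.

Three compounds have numbers in an assay on isolated protein for inhibition of Rho-associated protein kinase 1 (Homo sapiens); on this read-out higher numbers stand for weaker inhibition and lower numbers for stronger inhibition. Compound 1 `COc1cccc(CN(C(=O)c2c[nH]c3nc(-c4cn[nH]c4)ccc23)C2CC2)c1` gives 30 nM, compound 2 `COc1cccc(CNC(=O)c2cc3ccc(-c4cn[nH]c4)nc3n2CCCO)c1` gives 88 nM, and compound 3 `COc1cccc(CNC(=O)c2cn(CCN(C)C)c3cc(-c4cn[nH]c4)ccc23)c1` gives 5 nM. Compound 2 therefore holds the highest of the three numbers; the gap to compound 1, its nearest neighbour, and the gap to compound 3, its furthest, both lie beyond the scatter. Compound 4 `COc1cccc(CNC(=O)c2cc3ccc(-c4cn[nH]c4)nc3n2CCN(C)C)c1` is not yet measured. It differs from compound 2 in one place: dimethylamino in place of hydroxymethyl on a saturated chain carbon, two bonds along the chain from an aromatic nitrogen. For the measured compounds named here, no measured pair shows this change by itself. The core of compound 3 differs from that of compound 2, yet it carries the entering 2-(dimethylamino)ethyl chain; compound 3 gives 5 nM. Expected is a step that lowers the number beyond the scatter, a 2.5-fold lower number from compound 2 to compound 4 (0.40 log units; beyond the scatter). Compound 4 is estimated at 35 nM, within 10 nM to 120 nM.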

Compound 4, half-maximal inhibitory concentration: 243 nM
Estimate against measurement, compound 4: 6.9-fold (0.84 log units) below; the whole stated range lies below it.
By their numbers in this assay, from the lowest: compound 3; then compound 1; then compound 2; then compound 4.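

For the compounds shown here, on the core shared by compound 2 and compound 4, this is the first direct reading of the change at this position: in this assay, replacing 3-hydroxypropyl with 2-(dimethylamino)ethyl gives a 2.8-fold higher number from compound 2 to compound 4 (0.44 log units; beyond the scatter). The low number of compound 3 therefore cannot be carried over to this core as a gain from the entering chain. Nothing available explains the direction of this step. Still open, going by these compounds, is how a 3-(dimethylamino)propyl chain or a 2-hydroxyethyl chain would read on this core, which would separate the end group from the chain length.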